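A few compounds are considered here, and "the series" means these few. Any claim that something is new, unique, unknown or untested is made for them only; others in the source may bear on it.

compound 1 `FC(F)(F)c1ccc(CSc2nc(N3CCNCC3)cc(C(F)(F)F)n2)cc1` gives 6210 nM
compound 2 `FC(F)(F)c1ccc(CSc2nc(Sc3ncccn3)cc(C(F)(F)F)n2)cc1` gives 14000 nM

Among the compounds with values here, in a functional assay on NCI-H1975 cells (Homo sapiens) for inhibition, read by MTT assay, with a stated time of 72 h (a higher number here means a weaker inhibitor, a lower number a stronger inhibitor), compound 2 gives 14000 nM and is the weaker inhibitor of the two measured so far. Within the data shown here, only one measured step bears on what comes next. Placing (pyrimidin-2-yl)sulfanyl on an aromatic carbon in place of piperazin-1-yl gave a 2.3-fold higher number from compound 1 to compound 2 (0.35 log units; beyond the scatter) as a modest change. Compound 3 `FC(F)(F)c1ccc(CSc2nc(SC3=NCCS3)cc(C(F)(F)F)n2)cc1` keeps that sulfur and alters only the group attached to it: a group of 5 heavy atoms (3 carbon, 1 nitrogen, 1 sulfur; one five-membered non-aromatic ring with 2 hetero atoms) in place of a group of 6 heavy atoms (4 carbon, 2 nitrogen; one six-membered aromatic ring with 2 hetero atoms), on a sulfur is the whole difference from compound 2. Among the measured compounds shown here, no measurement yet shows the effect of changing this group on the sulfur, so the direction is open, and the modest 2.3-fold higher number from compound 1 to compound 2 (0.35 log units; beyond the scatter) suggests no large shift. The estimated step is a 1.4-fold lower number from compound 2 to compound 3 (0.15 log units; within the scatter) and could well prove small. Compound 3 is expected at 10000 nM with a likely range from 4000 nM to 25000 nM as an estimate.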

Compound 3, half-maximal inhibitory concentration: 24200 nM
Compound 3: the middle estimate sits 2.4-fold (0.38 log units) below what was measured, within the range that was stated.
By their numbers in this assay, from the lowest: compound 1; then compounds 2 and 3 (each within the scatter of the next).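

In this assay, replacing pyrimidin-2-yl on the sulfur with the five-membered non-aromatic ring gives a 1.7-fold higher number from compound 2 to compound 3 (0.24 log units; within the scatter), so this change of aromatic for non-aromatic ring leaves the two compounds indistinguishable. The group on the sulfur therefore shows no clear effect across this pair, even though the two rings differ in size and atoms. The wider comparison is clearer: a 3.9-fold higher number from compound 1 to compound 3 (0.59 log units; beyond the scatter), which runs in the same direction as a 2.3-fold higher number from compound 1 to compound 2 (0.35 log units; beyond the scatter), so with either group on the sulfur the number is higher than with piperazin-1-yl on the aromatic carbon.

From the compounds shown here alone, whether another amine on that carbon, such as morpholine or 4-methylpiperazine, would give a lower number than compound 1 stays open. Nothing available explains why piperazin-1-yl differs from the two sulfur-linked groups.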